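Fluorophenyl isomers in the cytotoxicity series

This account rests on a few compounds, and the source may have more. Where it says the series, first, only, none or still open, it means among the compounds named here.

- Compound 1 `CC(=O)Nc1ccc2oc(-c3ccc(F)cc3)cc(=O)c2c1`: 22000 nM
- Compound 2 `COc1ccccc1-c1oc2ccc(NC(C)=O)cc2c(=O)c1OC`: 108000 nM
- Compound 3 `COc1c(-c2ccccc2F)oc2ccc(NC(C)=O)cc2c1=O`: > 125000 nM, a limit and not a number

Compound 3 has only a limit in an ADME assay on THP-1 cells (Homo sapiens) for cytotoxicity, read by flow cytometry and propidium iodide staining, with a stated time of 72 h; on this read-out higher numbers stand for weaker inhibition and lower numbers for stronger inhibition: the limit of > 125000 nM in this assay, at which 1 of the 3 values shown sits. Compound 4 `COc1c(-c2ccc(F)cc2)oc2ccc(NC(C)=O)cc2c1=O` carries 4-fluorophenyl in place of 2-fluorophenyl on an aromatic carbon. Within the data shown here, the one measured step, an at least 1.1-fold higher number from compound 2 to compound 3 (0.06 log units; that floor lies within the scatter), shows no size beyond the scatter. Compound 1, which also carries 4-fluorophenyl, gives 22000 nM, so a moderately lower number is expected in this assay. The expected step is an at least 1.5-fold lower number from compound 3 to compound 4 (0.19 log units; that floor lies within the scatter). For compound 4 the estimate is 80000 nM, with an expected range of 30000 nM to 150000 nM.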

Compound 4, half-maximal inhibitory concentration: > 125000 nM
Compound 4 ended at the assay's limit (the forecaster's own chance of this, stated with the estimate: 30%); middle value at least 1.5-fold (0.19 log units) from the limit.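

In this assay compound 4 gives > 125000 nM, a limit and not a number. The change from 2-fluorophenyl to 4-fluorophenyl cannot be read, as both compounds sit at the limit: the limit of > 125000 nM in this assay, at which 2 of the 4 values shown sit.

The readable result is methoxy in place of hydrogen on an aromatic carbon, with an at least 5.6-fold higher number from compound 1 to compound 4 (0.75 log units; beyond the scatter), whereas an at least 1.1-fold higher number from compound 2 to compound 4 (0.06 log units; that floor lies within the scatter) gives no separation.

Going by these compounds, whether the methoxy step holds with 2-fluorophenyl remains open, as does where compound 3 and compound 4 lie beyond the limit. On these data alone, what an amine or a longer chain in place of methoxy would do also stays open.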